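The compounds below may be only part of what the source reports. "The series", "measured", "known", "first", "only" and "open" are said of these compounds alone.

Measured compounds:
Compound 1, `COc1cc2nc(Nc3ccc(S(C)(=O)=O)cc3)nc(N3CCC4CCC(C3)N4Cc3ccccc3)c2cc1OC`: 32.8%
Compound 2, `COc1cc2nc(Nc3ccc(S(C)(=O)=O)cc3)nc(N3CCC4CCC(C3)N4C(=O)OC(C)(C)C)c2cc1OC`: 37.5%
Compound 3, `COc1cc2nc(N3CCC4CCC(C3)N4C(=O)OC(C)(C)C)nc(Nc3ccc(S(C)(=O)=O)cc3)c2cc1OC`: 32.7%

All three were examined in a functional assay on HEK293 cells for agonist activity at Glucose-dependent insulinotropic receptor (Homo sapiens), read by cAMP accumulation, with a stated time of 60 min; a lower number here means a smaller maximal response, a higher number a larger maximal response. Compound 1 and compound 2 share one core and differ in a single place: the step of a number 4.7 percentage points lower from compound 2 to compound 1 (within the scatter) is benzyl in place of tert-butoxycarbonyl on an amine nitrogen in a ring. Compound 3 has the same atoms as compound 2 joined differently; the difference between the two cores is not broken down here. The three values lie within the scatter of one another.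

Compound 4, `COc1cc2nc(N3CCC4CCC(C3)N4Cc3ccccc3)nc(Nc3ccc(S(C)(=O)=O)cc3)c2cc1OC`, is not yet measured. It relates to compound 3 as compound 1 relates to compound 2, by the same change, (benzyl in place of tert-butoxycarbonyl on an amine nitrogen in a ring). The step from compound 3 to compound 4 is expected to be small, a number 2.7 percentage points lower from compound 3 to compound 4 (within the scatter), because a number 4.7 percentage points lower from compound 2 to compound 1 (within the scatter) stayed within the scatter. Compound 4 is therefore estimated at 30%, in a range from 20% to 42%.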

Compound 4, largest response reached (Emax), in percent of the reference or control that the assay uses: 23.4%
Estimate against measurement, compound 4: 6.6 percentage points above; measured number inside the range.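

In this assay the change of benzyl in place of tert-butoxycarbonyl on an amine nitrogen in a ring gives a number 9.3 percentage points lower from compound 3 to compound 4 (within the scatter) on the second core. Set beside the earlier step, the change reads alike on both cores: the same change on two cores in this assay, a number 4.7 percentage points lower (within the scatter) from compound 2 to compound 1 and a number 9.3 percentage points lower (within the scatter) from compound 3 to compound 4, 4.6 percentage points apart, within the scatter of two such steps. This shows that the change carried over between these two cores with no step beyond the scatter, but it does not show that it would carry to any other core, nor does it separate a real effect of the change from the scatter.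

The compounds shown leave open what the free ring amine or an acetyl group on that nitrogen would give. Also open, going by these compounds, is what a benzyl bearing a carboxylic acid would give there.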